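Removing the iodo group from the most potent of two compounds

The source may report more compounds than this note shows. Statements on the series, on what has been measured and on what is new or still open speak of the compounds shown alone.

Measured compounds:
- compound 1, `COC1=C(CC=C(C)C)C(=O)/C(=C(O)/C=C/c2ccccc2)C(=O)C1(CC=C(C)C)CC=C(C)C`: 13.3 uM
- compound 2, `CCCC1=C(OC)C(CCC)(CCC)C(=O)/C(=C(O)\C=C\c2ccc(I)cc2)C1=O`: 1.5 uM

Of the compounds shown here, two have so far been tested in a functional assay on KB cells (Homo sapiens) for antiproliferative activity, read by sulforhodamine B assay, with a stated time of 3 days; on this read-out higher numbers stand for an effect only at larger amounts of compound and lower numbers for an effect already at smaller amounts. Compound 1 gives 13.3 uM in this assay, while compound 2 gives 1.5 uM. Of these two numbers, compound 2 has the lower one, and the gap to compound 1 lies beyond the usual scatter of repeated measurements, so compound 2 is the more potent of the two.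

The next compound, compound 3, `CCCC1=C(OC)C(CCC)(CCC)C(=O)/C(=C(O)\C=C\c2ccccc2)C1=O`, keeps the whole core of compound 2 and changes only the ring at the far end of the chain: hydrogen in place of iodo on an aromatic carbon. For the measured compounds named here, no pair of measured compounds shows this change on its own, so the size of its effect is not yet known from this series. A halogen of this kind is often not neutral, and its loss is expected here to shift the number upward by a modest step, a 2.3-fold higher number from compound 2 to compound 3 (0.37 log units; beyond the scatter), though a result within the scatter of compound 2 would not be surprising. Compound 3 is therefore estimated at 3.5 uM in this assay, with a plausible range from 1.2 uM to 10 uM.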

Compound 3, concentration for half-maximal effect: 4.6 uM
Estimate against measurement, compound 3: 1.3-fold (0.12 log units) below, within the range that was stated.
By their numbers in this assay, from the lowest: compound 2; then compound 3; then compound 1.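

In this assay, for the compounds shown here, putting hydrogen in place of iodo on an aromatic carbon of the six-membered ring gives a 3.1-fold higher number from compound 2 to compound 3 (0.49 log units; beyond the scatter), and this is the first direct reading of what the iodo group adds. The change from 4-iodophenyl to phenyl therefore matters, but the step is modest and the iodo group is not needed for activity: without it, compound 3 still gives a measured value of 4.6 uM in this assay. No measurement on these compounds accounts for the size of this step.

A single exchange at this position cannot show whether another group there, such as a chloro group, a methoxy group or an amine, would give a lower or a higher number than iodo does. On these data alone, whether the same change would give a step of similar size on the core of compound 1 also stays open, since compound 1 differs from compound 3 in more than one place.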